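Trifluoromethyl for methyl: what happens to compound 3?

The source may report more compounds than this note shows. Statements on the series, on what has been measured and on what is new or still open speak of the compounds shown alone.

In an ADME assay on the whole organism (plasma) for pharmacokinetics, with Rattus norvegicus as the target, with a stated time of 24 h, at a dose of 10 mg/kg by the oral route (on this read-out lower numbers stand for lower exposure and higher numbers for higher exposure at the dose given), compound 1 `CCc1ccc2c(c1)c(-c1ccc[nH]c1=O)c(C(=O)NS(C)(=O)=O)n2Cc1cc(F)ccc1F` gives 35000 ng.h/mL and compound 2 `CCc1ccc2c(c1)c(-c1ccc[nH]c1=O)c(C(=O)NS(=O)(=O)C(C)C)n2Cc1cc(F)ccc1F` gives 411 ng.h/mL. Compound 3 `CCc1ccc2c(c1)c(-c1ccc[nH]c1=O)c(C(=O)NS(=O)(=O)C1CC1)n2Cc1cc(F)ccc1F` gives 6140 ng.h/mL, the middle of these three numbers. Compound 4 `O=C(NS(=O)(=O)C1CC1)c1c(-c2ccc[nH]c2=O)c2cc(CC(F)(F)F)ccc2n1Cc1cc(F)ccc1F` differs from compound 3 by trifluoromethyl in place of methyl on a saturated chain carbon bound to an aromatic carbon.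

The measured steps all change the group on a sulfonyl sulfur: an 85-fold lower number from compound 1 to compound 2 (1.93 log units; beyond the scatter), a 5.7-fold lower number from compound 1 to compound 3 (0.76 log units; beyond the scatter) and a 15-fold higher number from compound 2 to compound 3 (1.17 log units; beyond the scatter). Going by the values given here, none of them touches the place that changes here, so they give no direction for this step. They do show that a small change can move the numbers in this assay a long way, which argues for a wide range.

The starting point is therefore compound 3 at 6140 ng.h/mL, and no step beyond the scatter is expected, in either direction. The expected outcome is a 1.0-fold lower number from compound 3 to compound 4 (0.01 log units; within the scatter). For compound 4 the estimated value is 6000 ng.h/mL, with an expected range of 1200 ng.h/mL to 30000 ng.h/mL.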

Compound 4, area under the concentration-time curve: 379 ng.h/mL
Beside the measured number, compound 4's estimate is 16-fold (1.20 log units) above it, outside the stated range (below it).
By their numbers in this assay, from the lowest: compounds 4 and 2 (each within the scatter of the next); then compound 3; then compound 1.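

The earlier compounds shown here differed only in the group on the sulfonyl sulfur, so they showed nothing about the ethyl group on a saturated chain carbon bound to an aromatic carbon. In this assay, changing ethyl to 2,2,2-trifluoroethyl gives a 16-fold lower number from compound 3 to compound 4 (1.21 log units; beyond the scatter), so this place on the shared core can also move exposure a long way, and adding fluorine here is far from a neutral swap. No measurement shown here explains this drop in exposure.

Still open, going by these compounds, is whether the loss follows the fluorine atoms or simply the larger group, which a propyl chain or a 2-fluoroethyl group in this place could help to separate. Also open, on these data alone, is whether the same change would have a similar effect with methyl on the sulfonyl sulfur, as in compound 1.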